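The source may report more compounds than this note shows. Statements on the series, on what has been measured and on what is new or still open speak of the compounds shown alone.

Compound 1 `C=C/C=C\[C@H](C)[C@H](OC(N)=O)[C@@H](C)[C@H](O)[C@@H](C)C/C(C)=C\[C@H](C)[C@@H](O)[C@@H](C)/C=C\CCc1ccccc1`, compound 2 `C=C/C=C\[C@H](C)[C@H](OC(N)=O)[C@@H](C)[C@H](O)[C@@H](C)C/C(C)=C\[C@H](C)[C@@H](O)[C@@H](C)/C=C\CCc1cccc(O)c1` and compound 3 `C=C/C=C\[C@H](C)[C@H](OC(N)=O)[C@@H](C)[C@H](O)[C@@H](C)C/C(C)=C\[C@H](C)[C@@H](O)[C@@H](C)/C=C\CCc1ccc(C)c(O)c1` share one core and differ only in the aromatic ring at the chain end. In a functional assay on SK-OV-3 cells (Homo sapiens) for cytotoxicity (on this read-out higher numbers stand for weaker inhibition and lower numbers for stronger inhibition), compound 1 gives 350 nM, compound 2 gives 40 nM and compound 3 gives 410 nM. Compound 2 thus holds the lowest number of the three, with both others beyond the scatter: an 8.8-fold lower number from compound 1 to compound 2 (0.94 log units; beyond the scatter) and a 10-fold higher number from compound 2 to compound 3 (1.01 log units; beyond the scatter), while a 1.2-fold higher number from compound 1 to compound 3 (0.07 log units; within the scatter).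

Compound 4 `C=C/C=C\[C@H](C)[C@H](OC(N)=O)[C@@H](C)[C@H](O)[C@@H](C)C/C(C)=C\[C@H](C)[C@@H](O)[C@@H](C)/C=C\CCc1cc(F)cc(F)c1` is the unmeasured member; relative to compound 2 the change is 3,5-difluorophenyl in place of 3-hydroxyphenyl on a saturated chain carbon, two bonds along the chain from a double-bonded chain carbon. Within the data shown here, two measured steps bear on it. The step from compound 1 to compound 2 shows that the hydroxy on the aromatic ring goes with the lower number, and compound 4 gives that hydroxy up. The step from compound 2 to compound 3 shows that a further substituent on this ring can raise the number substantially. Among the measured compounds shown here, the fluorines in compound 4 have no measured precedent here. Compound 4 is therefore expected to lose the advantage of compound 2, with an estimated step of a 10-fold higher number from compound 2 to compound 4 (1.00 log units; beyond the scatter) in this assay. The estimate for compound 4 is 400 nM, within 120 nM to 1500 nM.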

Compound 4, half-maximal inhibitory concentration: 360 nM
Compound 4: the middle estimate sits 1.1-fold (0.05 log units) above what was measured; low and high end bracket the measured number.
By their numbers in this assay, from the lowest: compound 2; then compounds 1, 4 and 3 (each within the scatter of the next).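

In this assay, the 3,5-difluorophenyl group does not take over the role of 3-hydroxyphenyl at this chain end: the whole advantage of the hydroxy ring is lost (a 9.0-fold higher number from compound 2 to compound 4 (0.95 log units; beyond the scatter)). The two fluorines leave the number indistinguishable from that of the plain phenyl (a 1.0-fold higher number from compound 1 to compound 4 (0.01 log units; within the scatter)) and from that of the 3-hydroxy-4-methylphenyl ring (a 1.1-fold lower number from compound 3 to compound 4 (0.06 log units; within the scatter)), so among the four rings shown, only 3-hydroxyphenyl stands apart. No measurement available here explains this result.

The compounds shown leave open whether a methoxy or an amino group on the ring in place of the hydroxy would keep the low number of compound 2. Also open, going by these compounds, is whether a longer chain carrying the 3-hydroxyphenyl ring would hold that number.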